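Stripping the silicon-bearing group from compound 1

The compounds below may be only part of what the source reports. "The series", "measured", "known", "first", "only" and "open" are said of these compounds alone.

Compound 1, `COc1ccc(C2=C(c3cc(OC)c(OC)c(OC)c3)C(=O)CC2O[SiH2]C(C)(C)C)cc1`: in an ADME assay on PA-1 cells (Homo sapiens) for cytotoxicity, read by MTT assay, with a stated time of 72 h (on this read-out lower numbers stand for stronger inhibition and higher numbers for weaker inhibition), compound 1 gives > 100 ug/mL, a limit of the assay rather than a number.
Compound 2, `COC(=O)c1cc(C2=C(c3cc(OC)c(OC)c(OC)c3)C(=O)CC2O[SiH2]C(C)(C)C)ccc1OC`: compound 2 gives > 100 ug/mL, again a limit.
Compound 3, `COc1cc(C2=C(c3ccccc3)C(O[SiH2]C(C)(C)C)CC2=O)cc(OC)c1OC`: compound 3 gives > 100 ug/mL, also a limit.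

Compound 1 thus stands at the limit, as the limit of > 100 ug/mL in this assay, at which 3 of the 3 values shown sit, records for all three. Compound 4, `COc1ccc(C2=C(c3cc(OC)c(OC)c(OC)c3)C(=O)CC2O)cc1`, differs from compound 1 by the change (a hydrogen atom in place of a group of 5 heavy atoms (4 carbon, 1 silicon; no ring), on an oxygen on a saturated carbon). The measured steps a step that the two limits leave unreadable from compound 1 to compound 2, a step that the two limits leave unreadable from compound 1 to compound 3 and a step that the two limits leave unreadable from compound 2 to compound 3 touch other parts of the shared core and their sizes cannot be read, so none of them fixes a size for this step. With no movement beyond the scatter seen anywhere, compound 4 is expected to stay near the limit, an estimated step of a number no higher from compound 1 to compound 4 (the limit leaves the size open). Compound 4 is estimated at 100 ug/mL, within 40 ug/mL to 250 ug/mL.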

Compound 4, half-maximal inhibitory concentration: 3.38 ug/mL
The estimate for compound 4 lay 30-fold (1.47 log units) above the measured number; measured number below the stated range.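

Putting a hydrogen atom on this oxygen in place of the silicon-bearing group gives an at least 29-fold lower number from compound 1 to compound 4 (1.47 log units; beyond the scatter) in this assay. Among these compounds, the steps among compound 1, compound 2 and compound 3 cannot be read, so this is the first change here with a readable size. Compound 4 is also the only compound shown to leave the limit: the limit of > 100 ug/mL in this assay, at which 3 of the 4 values shown sit.

The compounds shown leave open how a small group on this oxygen, such as methyl or acetyl, would read. They also leave open whether the aromatic changes in compound 2 and compound 3 would move the number once the silicon-bearing group is gone.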